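Compound 2 to compound 3: 4-hydroxyphenyl replaces methyl

A few compounds are considered here, and "the series" means these few. Any claim that something is new, unique, unknown or untested is made for them only; others in the source may bear on it.

Of the compounds shown here, two have been tested so far in a toxicity assay on Huh-7 cells (Homo sapiens) for cytotoxicity, read by CCK-8 assay, with a stated time of 24 h; a higher number here means that more compound is tolerated, a lower number that less compound is tolerated: compound 1 (`O=c1cc(-c2ccc(Nc3ccc(F)cc3)cc2)oc2cc(O)c(O)c(O)c12`) and compound 2 (`CN1CCN(c2ccc(-c3cc(=O)c4c(O)c(O)c(O)cc4o3)cc2)CC1`). Compound 1 gives > 100000 nM, which is a limit of the assay. Compound 2 gives > 100000 nM, which is also a limit. Within the data shown here, compound 2 therefore has no numerical value, and the series so far rests on (the limit of > 100000 nM in this assay, at which 2 of the 2 values shown sit).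

Among the measured compounds shown here, compound 3 (`O=c1cc(-c2ccc(N3CCN(c4ccc(O)cc4)CC3)cc2)oc2cc(O)c(O)c(O)c12`) has 4-hydroxyphenyl in place of methyl on an amine nitrogen in a ring, the only difference from compound 2: 4-hydroxyphenyl in place of methyl on an amine nitrogen in a ring.

For the measured compounds named here, the one measured step bears on this change only loosely. It has 4-methylpiperazin-1-yl in place of (4-fluorophenyl)amino on an aromatic carbon, and it is a step that the two limits leave unreadable from compound 1 to compound 2. It gives no size to carry forward, so no shift beyond the scatter is expected in this assay, and another limit is the likeliest reading. The expected change is a number no higher from compound 2 to compound 3 (the limit leaves the size open). For compound 3 the estimate is 100000 nM, with an expected range of 40000 nM to 250000 nM.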

Compound 3, half-maximal cytotoxic concentration: > 100000 nM
Compound 3 was reported as a limit (the forecaster's own chance of this, stated with the estimate: 70%); the middle value lies on the limit itself.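

The step from compound 2 to compound 3 in this assay cannot be read, since both compounds are reported only as limits. The compounds shown leave open the concentration at which any of them becomes cytotoxic, and whether any change on the shared core would give a numerical value: the limit of > 100000 nM in this assay, at which 3 of the 3 values shown sit.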